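This account rests on a few compounds, and the source may have more. Where it says the series, first, only, none or still open, it means among the compounds named here.

Compound 1, `COc1ccc(Oc2ccc([N+](=O)[O-])cc2-c2ccsc2S(=O)(=O)N2CCN(C(=S)Nc3ccc(Cl)cc3)CC2)cc1OC`, in an assay for binding affinity to Apoptosis regulator Bcl-2 (Homo sapiens), read by fluorescence polarization, with stated times of 30 min and 20 min, tested at 100 uM (on this read-out lower numbers stand for less inhibition and higher numbers for more inhibition at the one concentration tested (going by the name of the read-out)), gives 18%. Compound 2, `COc1ccc(Oc2ccc([N+](=O)[O-])cc2-c2ccsc2S(=O)(=O)N2CCN(C(=O)Nc3ccc([N+](=O)[O-])cc3)CC2)cc1OC`, in this assay gives 19%. Compound 3, `COc1ccc(Oc2ccccc2-c2ccsc2S(=O)(=O)N2CCN(C(=O)Nc3ccc([N+](=O)[O-])cc3)CC2)cc1OC`, in this assay gives 17%.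

Two of these compounds share a core and differ in one place. From compound 2 to compound 1 the change is a group of 10 heavy atoms (7 carbon, 1 nitrogen, 1 sulfur, 1 chlorine; one six-membered aromatic ring of carbon only) in place of a group of 12 heavy atoms (7 carbon, 2 nitrogen, 3 oxygen; one six-membered aromatic ring of carbon only), on an amine nitrogen in a ring, and in this assay this step is a number 1 percentage points lower from compound 2 to compound 1 (within the scatter). The cores of compound 2 and compound 3 differ in one place as well, namely (hydrogen in place of nitro on an aromatic carbon), and in this assay that step is a number 2 percentage points lower from compound 2 to compound 3 (within the scatter). All three values therefore sit close together.

Compound 4, `COc1ccc(Oc2ccccc2-c2ccsc2S(=O)(=O)N2CCN(C(=S)Nc3ccc(Cl)cc3)CC2)cc1OC`, has not been measured in this assay. Going by the values given here, it differs from compound 3 by a group of 10 heavy atoms (7 carbon, 1 nitrogen, 1 sulfur, 1 chlorine; one six-membered aromatic ring of carbon only) in place of a group of 12 heavy atoms (7 carbon, 2 nitrogen, 3 oxygen; one six-membered aromatic ring of carbon only), on an amine nitrogen in a ring, which is the same change as the one made from compound 2 to compound 1, made here on the core of compound 3. Because the earlier step was a number 1 percentage points lower from compound 2 to compound 1 (within the scatter), the step from compound 3 to compound 4 in this assay is expected to be a number 1 percentage points lower from compound 3 to compound 4 (within the scatter). On that basis compound 4 is estimated to give 16% in this assay, most likely between 8% and 24%.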

Compound 4, a percentage reported as inhibition, at one concentration (the size of the read-out at that concentration, not a potency): 18%
Estimate against measurement, compound 4: 2 percentage points below; the range from low to high includes it.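

In this assay, the change on the amine nitrogen in the ring comes out as a number 1 percentage points higher from compound 3 to compound 4 (within the scatter), and set beside the earlier step it carries from one core to the other with no difference that can be told apart: the same change on two cores in this assay, a number 1 percentage points lower (within the scatter) from compound 2 to compound 1 and a number 1 percentage points higher (within the scatter) from compound 3 to compound 4, 2 percentage points apart, within the scatter of two such steps. Hydrogen in place of nitro gives no change at the digits printed from compound 1 to compound 4 (within the scatter), and this step also agrees with its earlier counterpart: the same change on two cores in this assay, a number 2 percentage points lower (within the scatter) from compound 2 to compound 3 and no change at the digits printed (within the scatter) from compound 1 to compound 4, 2 percentage points apart, within the scatter of two such steps. Going by these compounds alone, this does not show that either change has an effect that transfers, since every step here lies within the scatter and the agreement is only that of small steps among compounds read at one concentration.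

The compounds shown leave open whether any change at these two places can move the read-out beyond the scatter. As far as these compounds go, it also stays open whether an amine or a carboxylic acid on the aromatic carbon that carries the nitro group in compound 1, or a longer chain in place of the (4-nitrophenyl)carbamoyl group, would read differently.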